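The source may report more compounds than this note shows. Statements on the series, on what has been measured and on what is new or still open speak of the compounds shown alone.

Measured so far in a functional assay on MCF7 cells (Homo sapiens), read by MTT assay, with a stated time of 48 h; on this read-out higher numbers stand for weaker inhibition and lower numbers for stronger inhibition:
compound 1 `CCn1c(C(=O)NCCN(C)C)ccc1C(CC)(CC)c1ccc(OCC(=O)C(C)(C)C)c(C)c1` gives 520 nM
compound 2 `CCn1c(C(=O)NCCN)ccc1C(CC)(CC)c1ccc(OCC(=O)C(C)(C)C)c(C)c1` gives 75 nM
compound 3 `CCOC(=O)CN(C)C(=O)c1ccc(C(CC)(CC)c2ccc(OCC(O)C(C)(C)C)c(C)c2)n1CC` gives 9200 nM

Compound 3 at 9200 nM has the highest number of the three, beyond the scatter from both others. The next structure is compound 4 `CCN(CC)CCCNC(=O)c1ccc(C(CC)(CC)c2ccc(OCC(O)C(C)(C)C)c(C)c2)n1CC` with the change (3-(diethylamino)propyl)amino in place of ((ethoxycarbonyl)methyl)(methyl)amino on a carbonyl carbon on a carbonyl carbon. Going by the values given here, no measured step isolates this change. Among the compounds with values here, the one step available, a 6.9-fold lower number from compound 1 to compound 2 (0.84 log units; beyond the scatter) on the amine end of a side chain, shows only that a change there can exceed the scatter. Compound 1 and compound 2 also differ from compound 3 elsewhere, so they offer weak guidance. A lower number is expected, with an estimated step of a 7.7-fold lower number from compound 3 to compound 4 (0.88 log units; beyond the scatter) in this assay as a moderate move. For compound 4 the estimate is 1200 nM within a range of 250 nM to 6000 nM in this read-out.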

Compound 4, half-maximal inhibitory concentration: 190 nM
Beside the measured number, compound 4's estimate is 6.3-fold (0.80 log units) above it, and the stated range ends above it.
By their numbers in this assay, from the lowest: compound 2; then compound 4; then compound 1; then compound 3.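

In this assay, (3-(diethylamino)propyl)amino in place of ((ethoxycarbonyl)methyl)(methyl)amino on a carbonyl carbon gives a 48-fold lower number from compound 3 to compound 4 (1.69 log units; beyond the scatter). This large step shows that the whole group on this carbonyl carbon can strongly shift the read-out with the rest of the structure unchanged, whereas the earlier step covered only the amine end of a side chain. Nothing available explains the size of this step.

The whole group changes at once, so the contributions of its parts remain unseparated. Still open, as far as these compounds go, is how a carboxylic acid in place of the ester, or a pyrrolidine at the chain end, would read.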